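The compounds below may be only part of what the source reports. "The series", "measured", "known", "first", "only" and "open" are said of these compounds alone.

In a functional assay on CWR22R cells (Homo sapiens) for antiproliferative activity, read by CCK-8 assay, with a stated time of 6 days (a lower number here means a stronger inhibitor, a higher number a weaker inhibitor), compounds built on a shared core differ in one aromatic substituent. Compound 1 `CCN(c1ccc(C#N)c(Cl)c1)c1cc(-n2cnc3ccccc32)ccc1C` gives 3040 nM and compound 3 `CCN(c1ccc(C#N)c(Cl)c1)c1cc(-c2ccnn2C)ccc1C` gives 4330 nM, and these two values lie within the scatter: a 1.4-fold higher number from compound 1 to compound 3 (0.15 log units; within the scatter). Compound 2 `CCN(c1ccc(C#N)c(Cl)c1)c1cc(-c2ccccc2)ccc1C` gives only a limit of the assay, > 30000 nM.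

Compound 4 `CCN(c1ccc(C#N)c(Cl)c1)c1cc(-c2ccc(F)nc2)ccc1C` carries 6-fluoropyridin-3-yl in place of 1-methyl-1H-pyrazol-5-yl on an aromatic carbon. Going by the values given here, two measured steps bear on this: an at least 9.8-fold higher number from compound 1 to compound 2 (0.99 log units; beyond the scatter) and an at least 6.9-fold lower number from compound 2 to compound 3 (0.84 log units; beyond the scatter). The entering group is a six-membered aromatic ring, as phenyl is, so these steps point towards a higher number, though probably short of that limit. The expected change is a 2.1-fold higher number from compound 3 to compound 4 (0.32 log units; beyond the scatter). Compound 4 is estimated at 9000 nM, with an expected range from 3000 nM to 30000 nM.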

Compound 4, half-maximal inhibitory concentration: 16500 nM
Estimate against measurement, compound 4: 1.8-fold (0.26 log units) below; low and high end bracket the measured number.
By their numbers in this assay, from the lowest: compounds 1 and 3 (each within the scatter of the next); then compound 4. At a limit, above all of these: compound 2.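

In this assay, the six-membered 6-fluoropyridin-3-yl group at this position gives a modest loss against 1-methyl-1H-pyrazol-5-yl (a 3.8-fold higher number from compound 3 to compound 4 (0.58 log units; beyond the scatter)) and against 1H-benzimidazol-1-yl (a 5.4-fold higher number from compound 1 to compound 4 (0.73 log units; beyond the scatter)). Compound 4 also shows that a six-membered aromatic ring here can still give a measurable number. Against phenyl, the step gives only a floor (an at least 1.8-fold lower number from compound 2 to compound 4 (0.25 log units; that floor lies within the scatter)). Compound 2 stands at a limit: the limit of > 30000 nM in this assay, at which 1 of the 4 values shown sits.

From the compounds shown here alone, it remains open how a pyridin-3-yl group without the fluorine, or one bearing an amine or a methoxy group instead, would compare in this assay.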